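Adding a methyl to the aromatic nitrogen of compound 2

The source may hold more compounds than are shown below. What is called first, only, known or untested is meant among the compounds shown, and "the series" means these compounds.

In an ADME assay on the whole organism (plasma, strain CD) for pharmacokinetics, with Rattus norvegicus as the target, at a dose of 5 mg/kg by the oral route (a lower number here means less compound in the circulation, a higher number more compound in the circulation at the dose given), compound 2 (`COCCNC(=O)c1c(O)c2ncc(Cc3ccc(F)cc3)cc2[nH]c1=O`) gives 1650 ng.h/mL, the lower of the two numbers available. Compound 1 (`C[C@@H](CO)NC(=O)c1c(O)c2ncc(Cc3ccc(F)cc3)cc2n(C)c1=O`) gives 22600 ng.h/mL. The gap between these two numbers lies beyond the scatter. Compound 3 (`COCCNC(=O)c1c(O)c2ncc(Cc3ccc(F)cc3)cc2n(C)c1=O`) has methyl in place of hydrogen on an aromatic nitrogen. Among the compounds with values here, no measured pair isolates this change. Compound 1 bears the same methyl but has a different group in place of the (2-methoxyethyl)carbamoyl group, so it offers only a loose guide. A moderate rise in this assay, beyond the scatter, is expected, estimated as a 3.6-fold higher number from compound 2 to compound 3 (0.56 log units; beyond the scatter). The expected value for compound 3 is 6000 ng.h/mL, within a range of 2000 ng.h/mL to 20000 ng.h/mL.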

Compound 3, area under the concentration-time curve: 1850 ng.h/mL
Compound 3: the middle estimate sits 3.2-fold (0.51 log units) above what was measured; measured number outside the range, below it.
By their numbers in this assay, from the lowest: compounds 2 and 3 (each within the scatter of the next); then compound 1.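

In this assay, methyl in place of hydrogen on the aromatic nitrogen stays within the scatter (a 1.1-fold higher number from compound 2 to compound 3 (0.05 log units; within the scatter)), so with the (2-methoxyethyl)carbamoyl group present, this position shows no measurable response to the change. With that methyl common to both compounds, the large step lies at the amide-type nitrogen, where 2-methoxyethyl stands in place of 1-(hydroxymethyl)ethyl (a 12-fold lower number from compound 1 to compound 3 (1.09 log units; beyond the scatter)). Nothing measured here gives a reason for either result.

From the compounds shown here alone, it remains open whether the methyl step would hold with 1-(hydroxymethyl)ethyl on the amide-type nitrogen. Also open, going by these compounds, is how an ethyl on the aromatic nitrogen, or an amine or a longer chain on the amide-type nitrogen, would read.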